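Halogen swap on the benzylidene ring of a hydrazone

A few compounds are considered here, and "the series" means these few. Any claim that something is new, unique, unknown or untested is made for them only; others in the source may bear on it.

The account concerns compound 1 `Cc1ccc(C(=O)N/N=C/c2ccccc2F)c(O)c1` and compound 2 `Cc1ccc(C(=O)N/N=C/c2cccc(Cl)c2)c(O)c1`, two hydrazones built on a shared core that differ only in the halogen and its place on the second aromatic ring. In an ADME assay on cells (Mus musculus, strain BALB/C) for cytotoxicity, read by MTT assay, with a stated time of 24 h (a higher number here means that more compound is tolerated, a lower number that less compound is tolerated), compound 1 gives 362000 nM, and in the same assay compound 2 gives 636000 nM. Compound 1 thus holds the lower of the two numbers recorded, though the gap to compound 2 lies within the usual scatter of such measurements, so no order can be read from it.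

The step under consideration leads to compound 3 `Cc1ccc(C(=O)N/N=C/c2ccccc2Cl)c(O)c1`, which differs from compound 1 by chloro in place of fluoro on an aromatic carbon. For the measured compounds named here, no measured pair shows this precise change, and the only comparison available, between compound 1 and compound 2, shows no spread beyond the scatter. A step from compound 1 to compound 3 of no more than the scatter, in either direction, is therefore expected: a 1.2-fold higher number from compound 1 to compound 3 (0.09 log units; within the scatter). Compound 3 is estimated to give about 450000 nM, between 200000 nM and 1000000 nM.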

Compound 3, half-maximal cytotoxic concentration: 125000 nM
Estimate against measurement, compound 3: 3.6-fold (0.56 log units) above; the whole stated range lies above it.
By their numbers in this assay, from the lowest: compound 3; then compounds 1 and 2 (each within the scatter of the next).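

In this assay, chloro in place of fluoro on an aromatic carbon, ortho to a large group, gives a step beyond the scatter: a 2.9-fold lower number from compound 1 to compound 3 (0.46 log units; beyond the scatter), and it is the only such step shown. The earlier comparison of compound 1 and compound 2 gave no order, whereas compound 3 now holds the lowest of the three numbers, so the number at this position does change with the halogen it carries. Nothing available accounts for this change.

The compounds shown carry only fluoro or chloro on this ring, so it stays open how a bromo, a methoxy or an amine at the same place would read. On these data alone, this is also a single exchange, and whether chloro in place of fluoro gives a similar step on another aromatic carbon remains open.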